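A few compounds are considered here, and "the series" means these few. Any claim that something is new, unique, unknown or untested is made for them only; others in the source may bear on it.

Compound 1 `Cc1cc(/C=C/C#N)cc(C)c1Oc1cc(Nc2ccc(C#N)cc2)c(N)cc1S(N)(=O)=O`: > 21800 nM
Compound 2 `Cc1cc(/C=C/C#N)cc(C)c1Oc1cc(Nc2ccc(C#N)cc2)c(N)cc1C(F)(F)F`: 15000 nM
Compound 3 `Cc1cc(/C=C/C#N)cc(C)c1Oc1cc(Nc2ccc(C#N)cc2)c(N)cc1C(=O)O`: 14900 nM

These results come from an ADME assay on TZM cells (Homo sapiens) for cytotoxicity, read by XTT assay, with a stated time of 4 days; on this read-out lower numbers stand for higher toxicity in this test and higher numbers for lower toxicity in this test. The entry for compound 1, > 21800 nM, is a limit of the assay and not a number. Compound 3 stands level with compound 2, as a 1.0-fold lower number from compound 2 to compound 3 (0.00 log units; within the scatter) shows.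

Compound 4 `CNC(=O)c1cc(N)c(Nc2ccc(C#N)cc2)cc1Oc1c(C)cc(/C=C/C#N)cc1C` differs from compound 3 by methylamino in place of hydroxy on a carbonyl carbon. Among the compounds with values here, no measured step makes this exact change. The closest evidence is from the swaps of one group on an aromatic carbon: an at least 1.4-fold lower number from compound 1 to compound 2 (0.16 log units; that floor lies within the scatter), an at least 1.4-fold lower number from compound 1 to compound 3 (0.16 log units; that floor lies within the scatter) and a 1.0-fold lower number from compound 2 to compound 3 (0.00 log units; within the scatter). None of these shows a shift beyond the scatter, so none is expected here in this assay. The expected change is a 1.1-fold higher number from compound 3 to compound 4 (0.03 log units; within the scatter). For compound 4 the estimated value is 16000 nM, with an expected range of 8000 nM to 30000 nM.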

Compound 4, half-maximal cytotoxic concentration: > 9200 nM
Compound 4: a limit, no number; the forecaster's own chance of this, stated with the estimate: 40%; the middle value does not contradict the limit.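

The entry for compound 4 is a limit of the assay and not a number, and its steps from compound 1, compound 2 and compound 3 cannot be read: the limit of > 9200 nM in this assay, at which 1 of the 4 values shown sits.

The compounds shown leave open whether methylamino in place of hydroxy on a carbonyl carbon shifts this read-out at all.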